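A few compounds are considered here, and "the series" means these few. Any claim that something is new, unique, unknown or untested is made for them only; others in the source may bear on it.

In a functional assay on HepG2 cells (Homo sapiens) for inhibition, read by MTT assay, with a stated time of 48 h (on this read-out higher numbers stand for weaker inhibition and lower numbers for stronger inhibition), compound 1 (`CCOC(=O)C1=C(N/C=N/c2cccnc2Cl)Nc2[nH]nc(C)c2C1c1ccc(N(C)C)cc1`) gives 4890 nM as its reading, compound 2 (`CCOC(=O)C1=C(N/C=N/c2nnc(S(N)(=O)=O)s2)Nc2[nH]nc(C)c2C1c1ccc(N(C)C)cc1`) gives 38100 nM and compound 3 (`CCOC(=O)C1=C(N/N=C(/Cl)c2ccc([N+](=O)[O-])cc2)Nc2[nH]nc(C)c2C1c1ccc(N(C)C)cc1`) gives 55500 nM as its reading. Compound 3 thus stands level with compound 2 within the scatter (a 1.5-fold higher number from compound 2 to compound 3 (0.16 log units; within the scatter)) and well clear of compound 1 (an 11-fold higher number from compound 1 to compound 3 (1.05 log units; beyond the scatter)). Compound 4 (`CCOC(=O)C1=C(N/C=N/c2ccccn2)Nc2[nH]nc(C)c2C1c1ccc(N(C)C)cc1`) is reached from compound 3 by one change: a group of 8 heavy atoms (6 carbon, 2 nitrogen; one six-membered aromatic ring with 1 hetero atom) in place of a group of 12 heavy atoms (7 carbon, 2 nitrogen, 2 oxygen, 1 chlorine; one six-membered aromatic ring of carbon only), on an amine nitrogen and nothing else in the structure differs. The entering group holds one six-membered aromatic ring with 1 hetero atom and no chlorine.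

Compound 1 also carries a ring of that kind, which makes its step to compound 3 the most relevant one (an 11-fold higher number from compound 1 to compound 3 (1.05 log units; beyond the scatter)). Yet compound 2 also lacks the ring of compound 3 and still differs from compound 1 (a 7.8-fold higher number from compound 1 to compound 2 (0.89 log units; beyond the scatter)), so leaving the group of compound 3 does not by itself promise a lower number. A lower number is still expected in this assay but only compound 1 supports this, and compound 4 lacks its chlorine, so the expected change stops short of the full distance. The expected step is a 5.0-fold lower number from compound 3 to compound 4 (0.70 log units; beyond the scatter) as estimated here. Compound 4 is estimated at 11000 nM with a likely range from 3500 nM to 35000 nM on this read-out.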

Compound 4, half-maximal inhibitory concentration: 26200 nM
Compound 4: the middle estimate sits 2.4-fold (0.38 log units) below what was measured; the measured number falls inside the stated range.
By their numbers in this assay, from the lowest: compound 1; then compounds 4, 2 and 3 (each within the scatter of the next, the first and the last beyond it).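

On the double-bonded nitrogen, pyridin-2-yl does not match 2-chloropyridin-3-yl in this assay (a 5.4-fold higher number from compound 1 to compound 4 (0.73 log units; beyond the scatter)), so among compound 1 and compound 4, carrying a six-membered aromatic ring with one hetero atom does not by itself give the low number of compound 1. Pyridin-2-yl and 5-sulfamoyl-1,3,4-thiadiazol-2-yl cannot be told apart at this position (a 1.5-fold lower number from compound 2 to compound 4 (0.16 log units; within the scatter)), although the two rings differ in size and in their hetero atoms. Replacing the larger group of compound 3 on the amine nitrogen with pyridin-2-yl does lower the number, but only modestly (a 2.1-fold lower number from compound 3 to compound 4 (0.33 log units; beyond the scatter)), and this leaves compound 1 as the only one of the four set apart from all the others.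

Compound 1 and compound 4 differ both in the chlorine and in how the ring is attached, so these compounds leave open which of the two goes with the lower number, a question that a plain pyridin-3-yl on the same nitrogen would separate. No measurement is available here that explains any of these differences.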